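Dropping one trifluoromethyl from a urea: compound 3 to 4

The source may hold more compounds than are shown below. What is called first, only, known or untested is meant among the compounds shown, and "the series" means these compounds.

Compounds measured so far:
- Compound 1, `O=C(Nc1cccc(-n2cc(-c3ccncc3)c(-c3cc(O)cc(Cl)c3)n2)c1)Nc1ccc(Cl)c(Cl)c1`: -84.7%
- Compound 2, `COc1cc(Cl)cc(-c2nn(-c3cccc(NC(=O)Nc4ccc(Cl)c(C(F)(F)F)c4)c3)cc2-c2ccncc2)c1`: 4.81%
- Compound 3, `COc1cc(Cl)cc(-c2nn(-c3cccc(NC(=O)Nc4cc(C(F)(F)F)cc(C(F)(F)F)c4)c3)cc2-c2ccncc2)c1`: -24%

In a functional assay on LOX IMVI cells (Homo sapiens) for inhibition, read by sulforhodamine B assay, with a stated time of 48 h, tested at 10 uM (on this read-out lower numbers stand for a stronger effect and higher numbers for a weaker effect at the one concentration tested), compound 3 gives -24%, which places it second highest of the three numbers. Its nearest neighbour is compound 2, whose value in this assay is 4.81%, a gap beyond the scatter; compound 1 lies furthest away, giving -84.7% in this assay, also beyond the scatter.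

Compound 4, `COc1cc(Cl)cc(-c2nn(-c3cccc(NC(=O)Nc4cccc(C(F)(F)F)c4)c3)cc2-c2ccncc2)c1`, has not yet been measured. It differs from compound 3 in one place: hydrogen in place of trifluoromethyl on an aromatic carbon. Among the compounds with values here, no measured pair shows this exact change, so the expected size of the step rests only on the three values above. The step from compound 3 to compound 4 in this assay is expected to be modest and to run toward higher numbers, that is toward a weaker effect, with a real chance that it stays within the scatter. For compound 4 the estimated value in this assay is -5%, with a range from -40% to 30%, a step of a number 19 percentage points higher from compound 3 to compound 4 (beyond the scatter) that is expected rather than known.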

Compound 4, a percentage reported as activity, at one concentration (the size of the read-out at that concentration, not a potency): 4.64%
Beside the measured number, compound 4's estimate is 9.6 percentage points below it; measured number inside the range.
By their numbers in this assay, from the lowest: compound 1; then compound 3; then compounds 4 and 2 (each within the scatter of the next).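

In this assay, this carbon of the six-membered aromatic ring does matter: replacing trifluoromethyl with hydrogen gives a number 28.6 percentage points higher from compound 3 to compound 4 (beyond the scatter), so here the second trifluoromethyl goes with the stronger effect. A different carbon of that ring behaves otherwise, since hydrogen in place of chloro gives a number 0.2 percentage points lower from compound 2 to compound 4 (within the scatter), and compound 2 and compound 4 cannot be told apart in this assay. No measurement here explains why the two replacements differ.

From the compounds shown here alone, it remains open whether a smaller or different group on the first carbon, such as a methyl, a methoxy or a nitrile, would keep the effect seen with compound 3. A single pair also cannot show whether the same replacement would matter as much on a different core.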